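Aryl group swap from compound 2 to compound 4

The source may report more compounds than this note shows. Statements on the series, on what has been measured and on what is new or still open speak of the compounds shown alone.

Measured in an ADME assay on MCF7-DOX cells (Homo sapiens) for cytotoxicity, read by MTT assay, with a stated time of 48 h; on this read-out higher numbers stand for weaker inhibition and lower numbers for stronger inhibition:
- compound 1 `COc1cc(OC)c(C(=O)/C=C/c2cccc(N3CCNCC3)c2)c(O)c1CC=C(C)C`: 99900 nM
- compound 2 `COc1cc(OC)c(C(=O)/C=C/c2cccc(Cl)c2)c(O)c1CC=C(C)C`: 59500 nM
- compound 3 `COc1cc(O)c(C(=O)/C=C/c2cccc(N3CCN(C(=O)OC(C)(C)C)CC3)c2)c(OC)c1`: 56700 nM

Compound 2, at 59500 nM, lies within the scatter of both compound 1 and compound 3, so the three values give no firm order. Compound 4 `COc1cc(OC)c(C(=O)/C=C/c2ccc(N(C)C)cc2)c(O)c1CC=C(C)C` differs from compound 2 by 4-(dimethylamino)phenyl in place of 3-chlorophenyl on a double-bonded chain carbon bound to a double-bonded chain carbon. Among the measured compounds shown here, one measured step bears on this aromatic group: a 1.7-fold lower number from compound 1 to compound 2 (0.23 log units; within the scatter), chloro in place of piperazin-1-yl. For the measured compounds named here, no measured compound carries 4-(dimethylamino)phenyl, so this support is limited. No step beyond the scatter is therefore expected in this assay. The expected change is a 1.2-fold lower number from compound 2 to compound 4 (0.08 log units; within the scatter). For compound 4 the estimated value is 50000 nM, with an expected range of 20000 nM to 110000 nM.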

Compound 4, half-maximal inhibitory concentration: > 100000 nM
Compound 4 was reported as a limit; the forecaster's own chance of this, stated with the estimate: 10%; at least 2.0-fold (0.30 log units) between middle value and limit.
By their numbers in this assay, from the lowest: compounds 3, 2 and 1 (each within the scatter of the next). At a limit, above all of these: compound 4.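

Compound 4 is reported only as a limit in this assay, at > 100000 nM. Its step, an at least 1.6-fold higher number from compound 2 to compound 4 (0.22 log units; that floor lies within the scatter), gives no sign that 4-(dimethylamino)phenyl on this double-bonded chain carbon lowers the number relative to 3-chlorophenyl. The true size of the step stays unknown, since only its floor is fixed: the limit of > 100000 nM in this assay, at which 1 of the 4 values shown sits.

The swap changes both the substituent and its ring location, so the compounds shown cannot separate the two. As far as these compounds go, whether a carboxylic acid or a longer amine chain on this aromatic ring would give a lower number remains open.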